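A few compounds are considered here, and "the series" means these few. Any claim that something is new, unique, unknown or untested is made for them only; others in the source may bear on it.

Measured in a functional assay on HCT-116 cells (Homo sapiens) for antiproliferative activity, read by MTT assay, with a stated time of 72 h; on this read-out higher numbers stand for weaker inhibition and lower numbers for stronger inhibition
compound 1 `C=CC(=O)Nc1nc(-c2ccccc2)cs1` gives 18600 nM
compound 2 `C=CC(=O)Nc1nc(-c2ccc(C(F)(F)F)cc2)cs1` gives 4000 nM
compound 3 `C=CC(=O)Nc1nc(-c2ccccc2)c(C)s1` gives 20100 nM

Compound 1 sits at the weaker end of this small set, together with compound 3. The step of a 1.1-fold higher number from compound 1 to compound 3 (0.03 log units; within the scatter) leaves those two level, while the step of a 4.7-fold lower number from compound 1 to compound 2 (0.67 log units; beyond the scatter) sets the remaining compound clearly apart.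

Compound 4 `C=CC(=O)N(Cc1ccccc1)c1nc(-c2ccccc2)cs1` has not been measured yet. It keeps the core of compound 1 but has benzyl in place of hydrogen on an amide-type nitrogen.

Neither measured step touches that nitrogen. Both changes were made on aromatic carbons, so they offer only a rough sense of how far a single change can move the number in this series: one stayed within the scatter and the other was modest. Among the compounds with values here, no measured compound shows what a group on the amide nitrogen does, so the direction remains open. A slight lean towards a lower number rests only on compound 2 at 4000 nM and is weak evidence.

The step expected here is a 1.6-fold lower number from compound 1 to compound 4 (0.19 log units; within the scatter) and this estimate carries a wide margin. Compound 4 is expected at 12000 nM within a range from 3000 nM to 45000 nM on this estimate.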

Compound 4, half-maximal inhibitory concentration: > 30000 nM
Compound 4: only a limit was reported; the forecaster's own chance of this, stated with the estimate: 10%; at least 2.5-fold (0.39 log units) between middle value and limit.
By their numbers in this assay, from the lowest: compound 2; then compounds 1 and 3 (each within the scatter of the next). At a limit, above all of these: compound 4.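

Compound 4 is the only compound shown with a group on the amide-type nitrogen, and its reading in this assay is a limit of the assay, not a number: the limit of > 30000 nM in this assay, at which 1 of the 4 values shown sits. Benzyl in place of the amide hydrogen therefore gives a step that is known only from one side, an at least 1.6-fold higher number from compound 1 to compound 4 (0.20 log units; that floor lies within the scatter), so the compound may lie close to compound 1 or much further from it. What this position adds is a first, partial answer: the change on this nitrogen does not bring the clear drop to a lower number that trifluoromethyl brought on an aromatic carbon in compound 2.

The compounds shown leave open how far the true value of compound 4 lies past its limit, and whether the result belongs to benzyl in particular or to any group that replaces the amide hydrogen. A methyl on the same nitrogen, or a benzyl carrying an amine or a carboxylic acid on its ring, would help to separate these two readings.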